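A Bromo Substitution Carried from One Core to Another

The source may report more compounds than this note shows. Statements on the series, on what has been measured and on what is new or still open speak of the compounds shown alone.

Compound 1 `O=[N+]([O-])c1ccc(-c2cn3nc(Cc4ccc(Cl)cc4)sc3n2)cc1` and compound 3 `O=[N+]([O-])c1ccc(-c2nc3sc(Cc4ccc(Cl)cc4)nn3c2Br)cc1` differ in one place, (bromo in place of hydrogen on an aromatic carbon). In a functional assay on L1210 cells (Mus musculus) for cytotoxicity, with a stated time of 48 h (a lower number here means a stronger inhibitor, a higher number a weaker inhibitor), compound 1 gives 214000 nM. In this assay compound 3 gives 94000 nM. The change made a 2.3-fold lower number from compound 1 to compound 3 (0.36 log units; beyond the scatter).

Compound 2 `O=c1oc2ccccc2cc1-c1cn2nc(Cc3ccc(Cl)cc3)sc2n1` is built on a different core from compound 1; the difference between the two cores is not broken down here. In this assay compound 2 gives > 10000 nM, which is a limit of the assay and not a number. That value is the limit of > 10000 nM in this assay, at which 1 of the 3 values shown sits.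

Compound 4 `O=c1oc2ccccc2cc1-c1nc2sc(Cc3ccc(Cl)cc3)nn2c1Br` has not been measured in this assay. It differs from compound 2 by bromo in place of hydrogen on an aromatic carbon. For the measured compounds named here, this is the same kind of change as the one from compound 1 to compound 3, but the surroundings are described differently: in the first pair the change sits next to the ring atom that bears a group of 9 heavy atoms, in the second pair next to the ring atom that bears a large group.

Going by the values given here, the only measured example of this change is the step from compound 1 to compound 3, so the expectation for compound 4 rests on a 2.3-fold lower number from compound 1 to compound 3 (0.36 log units; beyond the scatter). Compound 4 is therefore expected to show a step that the limit leaves unreadable from compound 2 to compound 4 in this assay. Compound 4 is estimated at 20000 nM, with a likely range from 4000 nM to 100000 nM, and since compound 2 gave only a limit, the reading for compound 4 is expected quite possibly to be a limit again.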

Compound 4, half-maximal inhibitory concentration: 5200 nM
Beside the measured number, compound 4's estimate is 3.8-fold (0.59 log units) above it, and the stated range covers the measured number.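

In this assay, bromo in place of hydrogen on an aromatic carbon of the core of compound 2 comes out as an at least 1.9-fold lower number from compound 2 to compound 4 (0.28 log units; that floor lies within the scatter), and this figure is a floor rather than a measured size. Compound 2 stands at > 10000 nM, which is a limit of the assay and not a number. The change therefore goes with a lower number on both cores shown, but this rests on only two pairs, and it does not show that the change is worth the same amount on each core or that it would carry to any further core: the same change on two cores in this assay, a 2.3-fold lower number (0.36 log units; beyond the scatter) from compound 1 to compound 3 and an at least 1.9-fold lower number (0.28 log units; that floor lies within the scatter) from compound 2 to compound 4; the limit leaves it open whether they differ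

The compounds shown leave open how large the step on the second core would be if compound 2 had a reading inside the range of the assay, and so whether the core around the bromo alters the size of the step at all. They also leave open whether the lower number belongs to bromo alone, or would also appear with iodo, an amine or a methyl group on that same aromatic carbon of either core.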